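Notes on the Step from Compound 2 to Compound 4

A few compounds are considered here, and "the series" means these few. Any claim that something is new, unique, unknown or untested is made for them only; others in the source may bear on it.

Measured in a functional assay on HCT-116 cells (Homo sapiens) for inhibition, read by sulforhodamine B assay, with a stated time of 48 h, tested at 50 uM; a lower number here means less inhibition of growth, a higher number more inhibition of growth at the concentration tested:
- compound 1 `COc1cc(/C=C/C(=O)/C=C/c2cc(OC)c(OC)c(OC)c2)ccc1OCc1cn(CCOc2cc(=O)oc3ccccc23)nn1` gives 89%
- compound 2 `COc1cc(/C=C/C(=O)/C=C/c2cccc3ccccc23)ccc1OCc1cn(CCCOc2cc(=O)oc3ccccc23)nn1` gives 66%
- compound 3 `COc1cccc(/C=C/C(=O)/C=C/c2ccc(OCc3cn(CCOc4cc(=O)oc5ccccc45)nn3)c(OC)c2)c1` gives 70%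

Compound 2 shows the lowest of the three numbers; its nearest neighbour is compound 3, within the scatter, while compound 1 lies beyond the scatter above it.

Compound 4 `COc1ccc(/C=C/C(=O)/C=C/c2ccc(OCc3cn(CCCOc4cc(=O)oc5ccccc45)nn3)c(OC)c2)cc1` differs from compound 2 in one place: 4-methoxyphenyl in place of naphthalen-1-yl on a double-bonded chain carbon bound to a double-bonded chain carbon.

Going by the values given here, no measured step exchanges naphthalen-1-yl for any other group. Among the compounds with values here, the only measured step at this position, a number 19 percentage points lower from compound 1 to compound 3 (beyond the scatter), is a modest one and shows that the number of methoxy groups on the aryl at the chain end shifts the result. Compound 3, which carries 3-methoxyphenyl at the same place, sits within the scatter of compound 2, so a single-methoxy aryl there is not expected to move the number far. Compound 4 is therefore expected to show a number 4 percentage points higher from compound 2 to compound 4 (within the scatter), no step beyond the scatter. The estimate for compound 4 is 70%, expected between 58% and 82%.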

Compound 4, percent growth inhibition at one concentration: 54%
Beside the measured number, compound 4's estimate is 16 percentage points above it; the whole stated range lies above it.
By their numbers in this assay, from the lowest: compound 4; then compounds 2 and 3 (each within the scatter of the next); then compound 1.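

In this assay, 4-methoxyphenyl in place of naphthalen-1-yl gives a number 12 percentage points lower from compound 2 to compound 4 (beyond the scatter), which shows that a single-methoxy aryl at this place does not leave the number unchanged when it replaces the two-ring group. Going by these compounds alone, this is the first step read at this place with naphthalen-1-yl leaving, and with a number 19 percentage points lower from compound 1 to compound 3 (beyond the scatter) it gives two steps there, both downward, though the two pairs carry different chains on the other side of the core. No measurement bears on why the number falls with this exchange.

The compounds shown leave open whether the lower number follows the loss of the second aromatic ring or the entry of the methoxy oxygen, a question that plain phenyl at this place would address. Also open, on these data alone, is how an amine at this place, such as 4-(dimethylamino)phenyl, would read.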